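The source may report more compounds than this note shows. Statements on the series, on what has been measured and on what is new or still open speak of the compounds shown alone.

Among the compounds with values here, compound 1 `COc1ccc(S(=O)(=O)/C=C/c2ccccn2)cc1` gives the higher of the two numbers so far in an ADME assay on BV-2 cells (Mus musculus) for cytotoxicity, with a stated time of 24 h, tested at 10 uM (on this read-out higher numbers stand for a weaker effect at the one concentration tested and lower numbers for a stronger effect), namely compound 1 gives 100%, though the gap to compound 2 is within the scatter. Compound 2 `COc1ccc(S(=O)(=O)/C=C/c2cccc(Cl)n2)cc1`, carrying chloro in place of hydrogen on an aromatic carbon, gives in this assay compound 2 97%; the step of a number 3 percentage points lower from compound 1 to compound 2 (within the scatter) stays within the scatter. Compound 3 `COc1ccc(S(=O)(=O)/C=C/c2ccc(Cl)cn2)cc1` is not yet measured. It differs from compound 1 by chloro in place of hydrogen on an aromatic carbon. Within the data shown here, only the step to compound 2 bears on this, and it was small. Compound 3 is therefore expected to give 98%, between 88% and 106%. The expected step of a number 2 percentage points lower from compound 1 to compound 3 (within the scatter) means nothing beyond the scatter.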

Compound 3, a percentage reported as activity, at one concentration (the size of the read-out at that concentration, not a potency): 100%
Compound 3: middle estimate off by 2 percentage points, on the low side; low and high end bracket the measured number.
By their numbers in this assay, from the lowest: compounds 2, 1 and 3 (each within the scatter of the next).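

In this assay, chloro on an aromatic carbon two atoms from the ring nitrogen and para to a large group gives no change at the digits printed from compound 1 to compound 3 (within the scatter). This place on the ring therefore takes chloro without a step beyond the scatter, as does the place it holds in compound 2, which the earlier pair alone could not show. Nothing available accounts for this result. As far as these compounds go, whether an amine or a carboxylic acid at this position would leave the read-out equally undisturbed remains open. So does the effect of any group larger than chloro here.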